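The compounds below may be only part of what the source reports. "The series", "measured", "known", "first", "only" and "open" are said of these compounds alone.

Working notes on the series.

Three compounds carry numbers in a functional assay on L1210 cells (Mus musculus) for cytotoxicity, with a stated time of 48 h; on this read-out lower numbers stand for stronger inhibition and higher numbers for weaker inhibition. Compound 1 `CN(C)c1ccc(/C=C2\CCC/C(=C\c3ccccc3[N+](=O)[O-])C2=O)cc1` gives 164000 nM in this assay. Compound 2 `O=C1/C(=C/c2ccc(Cl)cc2)CCC/C1=C\c1ccc([N+](=O)[O-])cc1` gives 9410 nM in this assay, and compound 3 `O=C1/C(=C/c2ccc(Cl)cc2)CCC/C1=C\c1ccccc1[N+](=O)[O-]` gives 9380 nM in this assay; the two values sit within the scatter of each other. Compound 2 and compound 3 share the same atoms joined differently, and the difference between the two cores is not broken down here.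

One change is measured: dimethylamino in place of chloro on an aromatic carbon, which produced a 17-fold higher number from compound 3 to compound 1 (1.24 log units; beyond the scatter).

Compound 4 `CN(C)c1ccc(/C=C2\CCC/C(=C\c3ccc([N+](=O)[O-])cc3)C2=O)cc1` is not yet measured. It differs from compound 2 by dimethylamino in place of chloro on an aromatic carbon, the same change as that from compound 3 to compound 1, at a place described in the same words. Because compound 3 to compound 1 gave a 17-fold higher number from compound 3 to compound 1 (1.24 log units; beyond the scatter), and because compound 2 gives 9410 nM, a step of the same kind is expected here, estimated as a 16-fold higher number from compound 2 to compound 4 (1.20 log units; beyond the scatter). The estimate for compound 4 in this assay is 150000 nM, expected to lie between 50000 nM and 450000 nM; it rests on a single measured instance of the change, so the range is kept wide.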

Compound 4, half-maximal inhibitory concentration: > 500000 nM
Compound 4 was reported as a limit (the forecaster's own chance of this, stated with the estimate: 20%); at least 3.3-fold (0.52 log units) between middle value and limit.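

In this assay compound 4 gives > 500000 nM, which is a limit and not a number. Dimethylamino in place of chloro gave an at least 53-fold higher number from compound 2 to compound 4 (1.72 log units; beyond the scatter), and 4-nitrophenyl in place of 2-nitrophenyl gave an at least 3.0-fold higher number from compound 1 to compound 4 (0.48 log units; beyond the scatter); both steps are floors with no upper end. The change moved the number the same way on both cores, but its size did not carry over unchanged, and two cores set no rule for a third: the same change on two cores in this assay, a 17-fold higher number (1.24 log units; beyond the scatter) from compound 3 to compound 1 and an at least 53-fold higher number (1.72 log units; beyond the scatter) from compound 2 to compound 4, at least 3.0-fold (0.48 log units) apart, beyond the scatter of two such steps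

Still open, from the compounds shown here alone, is whether a plain amino group or a methoxy group in place of chloro would give a step of this kind on either core. Also open, going by these compounds, is whether a carboxylic acid or a nitrile in place of nitro would alter how the dimethylamino change behaves from one core to the other.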